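The source may report more compounds than this note shows. Statements on the series, on what has been measured and on what is new or still open speak of the compounds shown alone.

In a functional assay on MKN-45 cells (Homo sapiens) for cytotoxicity, read by MTT assay, with a stated time of 72 h (a higher number here means a weaker inhibitor, a lower number a stronger inhibitor), compound 1 `COc1cc2c(Oc3ccc(NC(=O)c4nn(-c5ccccc5)c(=O)c5ccccc45)cc3F)ccnc2cc1OCCCN1CCCC1` gives 530 nM, the lower of the two numbers in hand. Compound 2 `COc1ccc(-n2nc(C(=O)Nc3ccc(Oc4ccnc5cc(OCCCN6CCCC6)c(OC)cc45)c(F)c3)c3ccccc3c2=O)cc1` gives 1320 nM; the step of a 2.5-fold higher number from compound 1 to compound 2 (0.40 log units; beyond the scatter) concerns a methoxy on an aromatic carbon and carries no information about the far end of the chain. Compound 3 `COc1cc2c(Oc3ccc(NC(=O)c4nn(-c5ccccc5)c(=O)c5ccccc45)cc3F)ccnc2cc1OCCCN1CCN(C)CC1` differs from compound 1 by 4-methylpiperazin-1-yl in place of pyrrolidin-1-yl on a saturated chain carbon, three bonds along the chain from an oxygen on an aromatic ring. Among the measured compounds shown here, no measured step covers this exchange, so the expectation rests on compound 1 alone. Compound 3 is therefore expected to show a step of a 1.0-fold higher number from compound 1 to compound 3 (0.02 log units; within the scatter), within the usual scatter. For compound 3 the estimate in this assay is 550 nM, with a range of 250 nM to 1300 nM.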

Compound 3, half-maximal inhibitory concentration: 620 nM
Compound 3: middle estimate off by 1.1-fold (0.05 log units), on the low side, and the stated range covers the measured number.
By their numbers in this assay, from the lowest: compounds 1 and 3 (each within the scatter of the next); then compound 2.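

In this assay, among the compounds shown here, the first reading at the far end of the chain is 4-methylpiperazin-1-yl in place of pyrrolidin-1-yl, a 1.2-fold higher number from compound 1 to compound 3 (0.07 log units; within the scatter). At this position, the six-membered ring with 2 hetero atoms and the five-membered ring with 1 cannot be told apart in this assay. No supporting measurement bears on why the two read alike.

Open, on these data alone, is whether a morpholine or an open dimethylamino group at the chain end would read the same. A chain shorter or longer than the propyl linker also remains untested in the compounds shown.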